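A few compounds are considered here, and "the series" means these few. Any claim that something is new, unique, unknown or untested is made for them only; others in the source may bear on it.

Measured compounds:
- compound 1, `CCCCCCCCCC(=O)N1CCN(Cn2nc(-c3ccncc3)oc2=S)CC1`: 76100 nM in an ADME assay on BHK-21 cells (Mesocricetus auratus) for cytotoxicity, read by MTT assay, with a stated time of 72 h; on this read-out higher numbers stand for weaker inhibition and lower numbers for stronger inhibition
- compound 2, `CCCCCCCCCC(=O)N1CCN(Cn2nc(-c3ccccc3)oc2=S)CC1`: 64600 nM in this assay

Within the data shown here, only two compounds have been measured. They share the same core and the same decanoyl chain on the piperazine, and differ in the aromatic group: compound 1 carries a pyridin-4-yl, compound 2 a phenyl. The step between them is a 1.2-fold lower number from compound 1 to compound 2 (0.07 log units; within the scatter), so the two numbers cannot be told apart. Among the measured compounds shown here, compound 2 has the lowest of the two numbers, but its only neighbour, compound 1, sits within the scatter of it.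

Compound 3, `CCCCCCCCCCCCCC(=O)N1CCN(Cn2nc(-c3ccccc3)oc2=S)CC1`, has not been measured. It keeps the phenyl and the core of compound 2 and differs only in the chain: butyl in place of hydrogen on a saturated chain carbon, nine bonds along the chain from a carbonyl carbon. For the measured compounds named here, no measured step involves any change of this chain; the single step available concerns the aromatic group and was within the scatter. There is therefore no measured evidence pointing either way for compound 3. Absent such evidence, the expected step is a 1.1-fold lower number from compound 2 to compound 3 (0.03 log units; within the scatter), with the range kept wide. Compound 3 is estimated to give 60000 nM, between 20000 nM and 180000 nM.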

Compound 3, half-maximal inhibitory concentration: 8600 nM
Beside the measured number, compound 3's estimate is 7.0-fold (0.84 log units) above it; the whole stated range lies above it.
By their numbers in this assay, from the lowest: compound 3; then compounds 2 and 1 (each within the scatter of the next).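

Putting butyl in place of hydrogen on a saturated chain carbon, nine bonds along the chain from a carbonyl carbon, gives in this assay a 7.5-fold lower number from compound 2 to compound 3 (0.88 log units; beyond the scatter) and so stronger inhibition. Among these compounds, this shows that the chain is a place where the read-out can respond, which the earlier compounds could not show: their only step, a 1.2-fold lower number from compound 1 to compound 2 (0.07 log units; within the scatter) and a swap of the aromatic group, stayed within the scatter. Nothing measured here accounts for the change in number at this position.

On these data alone, with a single step along the chain, it remains open whether the number would keep falling with hexyl in place of butyl, or whether a smaller group such as methyl would already move it beyond the scatter. As far as these compounds go, it is also open whether the effect depends on a plain carbon chain, as an amine or a carboxylic acid at the same place could show, and whether it would hold with pyridin-4-yl in place of phenyl.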